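Chloro added to a benzyl ring on two different cores

A few compounds are considered here, and "the series" means these few. Any claim that something is new, unique, unknown or untested is made for them only; others in the source may bear on it.

Compound 1 `Nc1nc2cc(Cl)c(Cl)cc2n1Cc1ccc(Cl)c(Cl)c1` and compound 2 `Nc1nc2cc(Cl)c(Cl)cc2n1Cc1cccc(Cl)c1` share one core and differ in a single place. In a functional assay on KB cells (Homo sapiens) for inhibition (on this read-out lower numbers stand for stronger inhibition and higher numbers for weaker inhibition), compound 2 gives 65000 nM, and compound 1 gives 35000 nM. The change between them is chloro in place of hydrogen on an aromatic carbon, and the step it made was a 1.9-fold lower number from compound 2 to compound 1 (0.27 log units; within the scatter).

Compound 3 `Clc1cc2nc(Br)n(Cc3ccccc3)c2cc1Cl` carries a different core; the difference between the two cores is not broken down here. In this assay compound 3 gives > 100000 nM, which is a limit of the assay and not a number, namely (the limit of > 100000 nM in this assay, at which 1 of the 3 values shown sits).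

Compound 4 `Clc1cc2nc(Br)n(Cc3ccccc3Cl)c2cc1Cl` is not yet measured. It differs from compound 3 by chloro in place of hydrogen on an aromatic carbon. In compound 1 the entering chloro sits ortho to a chloro group and para to a large group, whereas in compound 4 it sits ortho to a large group, so this is the same kind of change, not the same change.

Because a 1.9-fold lower number from compound 2 to compound 1 (0.27 log units; within the scatter) stayed within the scatter, the step expected here is a number no higher from compound 3 to compound 4 (the limit leaves the size open). For compound 4 the expected value is 100000 nM, estimated to lie between 40000 nM and 300000 nM, with a real chance that only a limit is reported again.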

Compound 4, half-maximal inhibitory concentration: 78000 nM
Estimate against measurement, compound 4: 1.3-fold (0.11 log units) above; measured number inside the range.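

In this assay, within the data shown here, chloro in place of hydrogen on an aromatic carbon gave an at least 1.2-fold lower number from compound 3 to compound 4 (0.10 log units; that floor lies within the scatter), so the second core, like the first, shows no step that is clearly beyond the scatter. Set side by side, the two steps cannot be shown to match or to differ: the same change on two cores in this assay, a 1.9-fold lower number (0.27 log units; within the scatter) from compound 2 to compound 1 and an at least 1.2-fold lower number (0.10 log units; that floor lies within the scatter) from compound 3 to compound 4; the limit leaves it open whether they differ Compound 3 stands at > 100000 nM, which is a limit of the assay and not a number, so this pair fixes no size for the change and does not show that it carries over unchanged from one core to the other.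

The compounds shown leave open how much of any step belongs to the core and how much to the place of the chloro, as the entering chloro does not sit in the same place in the two pairs. They also leave open whether a methoxy group or a carboxylic acid on that ring would give a step clearly beyond the scatter.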